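A few compounds are considered here, and "the series" means these few. Any claim that something is new, unique, unknown or untested is made for them only; others in the source may bear on it.

Compound 1 `COc1cc([C@H]2C[C@@]2(CO)C(=O)NCc2ccc(C)cc2)cc(OC)c1OC`: > 100000 nM in a functional assay on HeLa cells (Homo sapiens) for cytotoxicity, read by MTT assay, with a stated time of 48 h; on this read-out lower numbers stand for stronger inhibition and higher numbers for weaker inhibition.
Compound 2 `COc1cc([C@@H]2C[C@@]2(CO)C(=O)Nc2ccccc2Cl)cc(OC)c1OC`: 13300 nM.
Compound 3 `CCOC(=O)[C@@]1(C(=O)Nc2ccccc2Cl)C[C@@H]1c1cc(OC)c(OC)c(OC)c1`: > 100000 nM.

Compound 3 gives only a limit in this assay, not a number. Compound 1 likewise gives only a limit. Of the three values shown, one alone is a number, that of compound 2, and the two others sit at the limit, as noted in the limit of > 100000 nM in this assay, at which 2 of the 3 values shown sit. Compound 4 `COc1cc([C@H]2C[C@@]2(CO)C(=O)Nc2ccccc2Cl)cc(OC)c1OC` is not yet measured. It differs from compound 3 in one place: hydroxymethyl in place of ethoxycarbonyl on a saturated ring carbon. Within the data shown here, because compound 3 itself is only a limit, the size of the step cannot be fixed from it, and no step between measured compounds is available. Compound 4 is expected to reach a number below the limit, with the step of an at least 3.3-fold lower number from compound 3 to compound 4 (0.52 log units; beyond the scatter) estimated as a gain beyond the scatter. The estimate for compound 4 is 30000 nM, ranging from 8000 nM to 100000 nM.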

Compound 4, half-maximal inhibitory concentration: > 100000 nM
Compound 4: only a limit was reported; the forecaster's own chance of this, stated with the estimate: 40%; at least 3.3-fold (0.52 log units) between middle value and limit.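

Among these compounds, the only readable step, an at least 7.5-fold higher number from compound 2 to compound 4 (0.87 log units; beyond the scatter), shows that with hydroxymethyl and 2-chlorophenyl both kept, the configuration drawn at a saturated ring carbon separates a measurable value from a limit in this assay: the fact that compounds 2 and 4 differ only in the configuration as drawn. Compound 4 gives only a limit, > 100000 nM, so hydroxymethyl does not bring a measurable value in this configuration. The steps to compound 4 from compound 3 and from compound 1 cannot be read: the limit of > 100000 nM in this assay, at which 3 of the 4 values shown sit.

As far as these compounds go, it remains open how an amine or a carboxylic acid in place of hydroxymethyl on this ring carbon would read in either configuration.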